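From a Chloroethyl Amide to a Butenyl Amide

The source may report more compounds than this note shows. Statements on the series, on what has been measured and on what is new or still open speak of the compounds shown alone.

Three compounds share a trimethoxyphenyl-bearing core and were tested in a functional assay on KYSE-450 cells (Homo sapiens) for inhibition, read by MTT assay, with a stated time of 48 h; a higher number here means a weaker inhibitor, a lower number a stronger inhibitor. Compound 1 `COc1ccc(CN(C(=O)CCCl)c2cc(OC)c(OC)c(OC)c2)cc1O` gives 110 nM in this assay, the lowest of the three numbers. The other two carry a plain amine in place of the amide: compound 2 `COc1cc(NCc2cccc(O)c2)cc(OC)c1OC` gives 71300 nM in this assay, and compound 3 `COc1ccc(CNc2cc(OC)c(OC)c(OC)c2)cc1Cl` gives 47800 nM in this assay, both far beyond the scatter away from compound 1. Going by the values given here, no single-point step connects these measured compounds, so only the bare values can be compared.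

Compound 4 `CC/C=C/C(=O)N(Cc1ccc(OC)c(O)c1)c1cc(OC)c(OC)c(OC)c1` keeps the amide of compound 1 and changes only its acyl chain: but-1-en-1-yl in place of 2-chloroethyl on a carbonyl carbon. Among the compounds with values here, no comparable step has been measured, so the size of the change is open. Compound 4 is expected to stay close to compound 1, with a step of a 2.3-fold higher number from compound 1 to compound 4 (0.36 log units; beyond the scatter) that may reach just beyond the scatter toward a higher number. Compound 4 is therefore estimated at 250 nM in this assay, within a range from 60 nM to 1500 nM.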

Compound 4, half-maximal inhibitory concentration: 72 nM
Compound 4: middle estimate off by 3.5-fold (0.54 log units), on the high side; the range from low to high includes it.
By their numbers in this assay, from the lowest: compounds 4 and 1 (each within the scatter of the next); then compounds 3 and 2 (each within the scatter of the next).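

On the carbonyl carbon, but-1-en-1-yl in place of 2-chloroethyl gives a 1.5-fold lower number from compound 1 to compound 4 (0.18 log units; within the scatter) in this assay and stays within the usual scatter. Compound 1 therefore does not depend on its chlorine for a value of this order: compound 4, with a four-carbon chain holding one double bond and no halogen, reads alike in this position. Nothing shown explains why these two different chains read alike.

From the compounds shown here alone, whether the double bond matters at all stays open, and a saturated butyl chain on the same carbonyl would test that directly. The share of the amide itself also stays open, since the plain amine matching compound 1 in every other place is not among the compounds shown.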